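Swapping a Phenyl for a Furan-2-yl in Compound 4

The source may report more compounds than this note shows. Statements on the series, on what has been measured and on what is new or still open speak of the compounds shown alone.

Compound 1 `O=C(Cn1c(-c2ccccc2)cc(-c2ccccc2)c1-c1ccco1)Nc1nc2ccccc2s1` was examined in an ADME assay on HEK-293T cells (Homo sapiens) for cytotoxicity, read by MTT assay, with a stated time of 72 h; a lower number here means a stronger inhibitor, a higher number a weaker inhibitor. In this assay compound 1 gives < 50000 nM, which is a limit of the assay rather than a measured number. Compound 2 `O=C(Cn1c(-c2ccccc2)cc(-c2ccccc2)c1-c1ccco1)Nc1ccccn1` shares the core, and the step between the two is a step that the two limits leave unreadable from compound 1 to compound 2. In this assay compound 2 gives < 50000 nM, again only a limit. Compound 3 `O=C(Cn1c(-c2ccccc2)cc(-c2ccccc2)c1-c1ccccc1)Nc1nc2ccccc2s1` shares the core as well, and the step between the two is a step that the two limits leave unreadable from compound 1 to compound 3. In this assay compound 3 gives < 50000 nM, also a limit. All three results sit at the limit of < 50000 nM in this assay, at which 3 of the 3 values shown sit.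

Compound 4 `O=C(Cn1c(-c2ccccc2)cc(-c2ccco2)c1-c1ccco1)Nc1nc2ccccc2s1` has not yet been measured. It differs from compound 1 by furan-2-yl in place of phenyl on an aromatic carbon. The nearest measured comparison is the step from compound 1 to compound 3, which exchanges the same two groups at the same place in the opposite direction; its size cannot be read because both of its values sit at the limit of < 50000 nM in this assay, at which 3 of the 3 values shown sit. With no readable step available, compound 4 is expected to remain at the limit, so the expected step of a number no lower from compound 1 to compound 4 (the limit leaves the size open) is none beyond the scatter. Compound 4 is therefore estimated at 50000 nM, within a range from 20000 nM to 100000 nM.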

Compound 4, half-maximal inhibitory concentration: < 50000 nM
Compound 4 gave a limit, no number (the forecaster's own chance of this, stated with the estimate: 85%); the middle value lies on the limit itself.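

No step can be read from compound 1 to compound 4, since each gives only a limit in this assay. How strongly any of the four compounds acts, and whether phenyl or furan-2-yl at this place matters, stays open because every result rests on the same boundary: the limit of < 50000 nM in this assay, at which 4 of the 4 values shown sit.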